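Swapping chloro for methyl on the aryl ketone chain

The compounds below may be only part of what the source reports. "The series", "measured", "known", "first", "only" and "open" are said of these compounds alone.

Measured compounds:
- compound 1, `O=C(CCC(=O)c1ccc(Cl)c(Cl)c1)NCCCO`: 300 mg/kg
- compound 2, `O=C(CCC(=O)c1ccc(Cl)cc1)NCCCO`: 300 mg/kg
- compound 3, `Cc1ccc(C23CCC(=O)N2CCCO3)cc1`: < 50 mg/kg

Compound 1 `O=C(CCC(=O)c1ccc(Cl)c(Cl)c1)NCCCO` and compound 2 `O=C(CCC(=O)c1ccc(Cl)cc1)NCCCO` were tested in a functional assay on the whole organism (Central nervous system) for activation, with Mus musculus as the target; a lower number here means that less compound is needed, a higher number that more compound is needed for the effect; in this assay compound 1 gives 300 mg/kg and compound 2 gives 300 mg/kg, so compound 2 stands level with compound 1. The step from the former to the latter, no change at the digits printed from compound 1 to compound 2 (within the scatter), removed one chloro without any shift beyond the scatter. Compound 3 `Cc1ccc(C23CCC(=O)N2CCCO3)cc1` was also run, and its value in this assay is a limit, < 50 mg/kg; of the three values shown, one sits at the limit of < 50 mg/kg in this assay, at which 1 of the 3 values shown sits.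

The compound not yet measured is compound 4 `Cc1ccc(C(=O)CCC(=O)NCCCO)cc1`. It differs from compound 2 only in methyl in place of chloro on an aromatic carbon. Among the measured compounds shown here, the one measured step that bears on this, no change at the digits printed from compound 1 to compound 2 (within the scatter), altered the same ring position without moving the number, so the exchange of chloro for methyl is expected to behave alike, giving a step of no change at the digits printed from compound 2 to compound 4 (within the scatter). Compound 4 is therefore estimated at 300 mg/kg, within 150 mg/kg to 600 mg/kg.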

Compound 4, dose for half-maximal effect: 300 mg/kg
Compound 4: the middle estimate sits on the measured number at the digits printed; the measured number falls inside the stated range.
By their numbers in this assay, from the lowest: compounds 1, 2 and 4 (each within the scatter of the next). At a limit, below all of these: compound 3.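

In this assay, the exchange of chloro for methyl gives no change at the digits printed from compound 2 to compound 4 (within the scatter). Among the compounds shown here, the earlier pair showed only that one chloro of compound 1 could go while the other stayed on the ring; this step shows that the remaining chloro, para to a large group, can also give way, here to a methyl of the same heavy-atom count, with no shift beyond the scatter. No measurement shown offers a reason for this flat result.

As far as these compounds go, what remains open is whether a group of a different kind at this position, such as an amine, a carboxylic acid or a longer chain, would also leave the number unmoved. Also open is how a plain hydrogen at this position would read, since every chain compound shown carries a group there.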